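Moving the Fluorine Across the Aryl Ring

The source may hold more compounds than are shown below. What is called first, only, known or untested is meant among the compounds shown, and "the series" means these compounds.

Compound 1 `CCNC(=O)c1cc(Oc2ccc(NC(=O)c3cc4cccnc4n(-c4ccc(F)cc4)c3=O)cc2)ccn1`: 220 nM
Compound 2 `CCCNC(=O)c1cc(Oc2ccc(NC(=O)c3cc4cccnc4n(-c4ccccc4F)c3=O)cc2)ccn1`: 390 nM

In a functional assay on NCI-H460 cells (Homo sapiens) for antiproliferative activity, read by MTT assay, with a stated time of 72 h (on this read-out lower numbers stand for stronger inhibition and higher numbers for weaker inhibition), compound 2 gives the higher of the two numbers, but its gap to compound 1 lies within the usual scatter, so the two cannot be ranked. Compound 3 `CCCNC(=O)c1cc(Oc2ccc(NC(=O)c3cc4cccnc4n(-c4ccc(F)cc4)c3=O)cc2)ccn1` differs from compound 2 by 4-fluorophenyl in place of 2-fluorophenyl on an aromatic nitrogen. Within the data shown here, no pair of measured compounds isolates this change. Compound 1 carries the same 4-fluorophenyl with a shorter amide chain and gives 220 nM in this assay. The step from compound 2 to compound 3 is therefore expected to be small, not beyond the scatter: a 1.4-fold lower number from compound 2 to compound 3 (0.16 log units; within the scatter). Compound 3 is estimated at 270 nM, in a range from 110 nM to 650 nM.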

Compound 3, half-maximal inhibitory concentration: 120 nM
For compound 3 the middle estimate is 2.3-fold (0.35 log units) above the measured one; low and high end bracket the measured number.
By their numbers in this assay, from the lowest: compounds 3, 1 and 2 (each within the scatter of the next, the first and the last beyond it).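

With the amide chain the same, 4-fluorophenyl in place of 2-fluorophenyl on the aromatic nitrogen now stands as a step of its own in this assay, and it gives a 3.3-fold lower number from compound 2 to compound 3 (0.51 log units; beyond the scatter). Methyl in place of hydrogen on the amide chain, with the 4-fluorophenyl kept, gives a 1.8-fold lower number from compound 1 to compound 3 (0.26 log units; within the scatter), so this chain change cannot be told from scatter. No measurement at hand accounts for the effect of the fluorine's position. Open remains how a plain phenyl on that nitrogen would compare, and whether a butyl chain on the amide would keep the number of compound 3 120 nM.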